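A few compounds are considered here, and "the series" means these few. Any claim that something is new, unique, unknown or untested is made for them only; others in the source may bear on it.

Measured compounds:
- compound 1 `Cc1cc(O)c(C2=NN(c3ccc(S(N)(=O)=O)cc3)C(c3ccccc3O)C2)cc1Cl`: 6510 nM
- compound 2 `Cc1cc(O)c(C2=NN(c3ccc(S(N)(=O)=O)cc3)C(c3ccccc3Cl)C2)cc1Cl`: 6320 nM

Among the compounds with values here, in a functional assay on HOP-92 cells (Homo sapiens) for antiproliferative activity, with a stated time of 48 h (on this read-out lower numbers stand for stronger inhibition of growth and higher numbers for weaker inhibition of growth), compound 2 gives 6320 nM, the lowest of the two numbers measured so far, and its only neighbour, compound 1, gives 6510 nM. Within the data shown here, the single measured step, a 1.0-fold lower number from compound 1 to compound 2 (0.01 log units; within the scatter), shows that swapping a hydroxy for a chloro on the phenyl attached to the saturated ring carbon left the result unchanged.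

Compound 3 `Cc1cc(O)c(C2=NN(c3ccc(S(N)(=O)=O)cc3)C(/C=C/c3ccccc3)C2)cc1Cl` differs from compound 2 by 2-phenylethenyl in place of 2-chlorophenyl on a saturated ring carbon. Among the measured compounds shown here, no measured pair covers an exchange of this kind, in which the whole aromatic group at that carbon gives way to a chain carrying a double bond and a phenyl. For the measured compounds named here, the one step that is known touched the same position and stayed within the scatter, so there is no sign yet that this position drives the result, but the present change is larger than a single group swap. The expected step of a 1.1-fold lower number from compound 2 to compound 3 (0.02 log units; within the scatter) is therefore small, with a wide margin either way. Compound 3 is expected to give 6000 nM, in the range 2500 nM to 15000 nM.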

Compound 3, concentration for total growth inhibition: 8480 nM
For compound 3 the middle estimate is 1.4-fold (0.15 log units) below the measured one; low and high end bracket the measured number.
By their numbers in this assay, from the lowest: compounds 2, 1 and 3 (each within the scatter of the next).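

In this assay the step of a 1.3-fold higher number from compound 2 to compound 3 (0.13 log units; within the scatter) and the step of a 1.3-fold higher number from compound 1 to compound 3 (0.11 log units; within the scatter) both stay within the scatter, even though the whole 2-chlorophenyl or 2-hydroxyphenyl group on the saturated ring carbon gives way here to 2-phenylethenyl. Until now this position had only shown that one substituent on the phenyl could be swapped for another, whereas it now shows that the aromatic group can also be replaced by a chain with a double bond that carries the phenyl, and the read-out still does not separate the compounds. Nothing is available that would explain why these compounds read alike.

As far as these compounds go, what remains open is whether a group of a different kind on this carbon, such as an amine, a carboxylic acid or a longer saturated chain, would move the number beyond the scatter. Also open is whether the 4-sulfamoylphenyl group or the 5-chloro-2-hydroxy-4-methylphenyl group matters more to the result than this carbon does, since both stay the same in every compound shown.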